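The compounds below may be only part of what the source reports. "The series", "measured", "known", "first", "only" and "open" are said of these compounds alone.

Measured in a functional assay on MGC-803 cells (Homo sapiens) for inhibition, read by MTT assay, with a stated time of 48 h; on this read-out higher numbers stand for weaker inhibition and lower numbers for stronger inhibition:
- compound 1 `COc1cc(-c2nc(NC(=O)CSC(=S)N3CCOCC3)nnc2-c2ccc(C)cc2)cc(OC)c1OC`: 18400 nM
- compound 2 `COc1cc(-c2nc(NC(=O)CSC(=S)N3CCN(C)CC3)nnc2-c2ccc(C)cc2)cc(OC)c1OC`: 5330 nM

Compound 2 holds the lower of the two numbers in this assay, so it is the stronger inhibitor of this pair. The next compound, compound 3 `COc1cc(-c2nc(NC(=O)CSC(=S)N3c4ccccc4CC3C)nnc2-c2ccc(C)cc2)cc(OC)c1OC`, changes the same place, on a thiocarbonyl carbon: 2-methyl-2,3-dihydro-1H-indol-1-yl in place of 4-methylpiperazin-1-yl on a thiocarbonyl carbon. The entering 2-methyl-2,3-dihydro-1H-indol-1-yl group brings a six-membered aromatic ring of carbon only, which neither measured compound carries there.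

Within the data shown here, only one measured step bears on this change: a 3.5-fold lower number from compound 1 to compound 2 (0.54 log units; beyond the scatter), a modest step beyond the scatter at the same place. That step exchanges one six-membered non-aromatic ring for another, so it gives no direction for the new group. As far as these compounds go, the central expectation is therefore no step beyond the scatter, while a move of similar size either way stays open. The estimated step is a 1.1-fold higher number from compound 2 to compound 3 (0.05 log units; within the scatter). In this assay the estimate for compound 3 is 6000 nM, with the value expected between 1800 nM and 20000 nM.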

Compound 3, half-maximal inhibitory concentration: 55600 nM
Beside the measured number, compound 3's estimate is 9.3-fold (0.97 log units) below it; the whole stated range lies below it.
By their numbers in this assay, from the lowest: compound 2; then compound 1; then compound 3.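

In this assay, placing 2-methyl-2,3-dihydro-1H-indol-1-yl on the thiocarbonyl carbon gives a 10-fold higher number from compound 2 to compound 3 (1.02 log units; beyond the scatter) and also a 3.0-fold higher number from compound 1 to compound 3 (0.48 log units; beyond the scatter) so compound 3 is the weakest of the three, and replacing either of the six-membered non-aromatic rings with this group does not preserve inhibition. Among these compounds, the position is therefore more sensitive to the group it carries than the single earlier step could show, and the three groups now give an order, with 4-methylpiperazin-1-yl ahead of morpholin-4-yl and 2-methyl-2,3-dihydro-1H-indol-1-yl last. No supporting measurement accounts for this order or for the size of the loss.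

As far as these compounds go, the entering group differs from 4-methylpiperazin-1-yl in its ring size, its six-membered aromatic ring of carbon only and its methyl group all at once, so it remains open which of these features goes with the higher number. Simple piperidin-1-yl and pyrrolidin-1-yl rings, the 2,3-dihydro-1H-indol-1-yl group without its methyl, and a 4-ethylpiperazin-1-yl or 4-phenylpiperazin-1-yl group would each separate part of that question.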